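Swapping a sulfonyl cap for a pyrrolidine amide

The source may hold more compounds than are shown below. What is called first, only, known or untested is meant among the compounds shown, and "the series" means these compounds.

Compound 1 `O=S(=O)(NC1CCN(S(=O)(=O)c2ccccc2)CC1)c1cc(S(=O)(=O)c2ccccc2)ccc1C(F)(F)F` is the reference point of this small set. In an assay on U2OS cells for inhibition of secreted frizzled-related protein 1 (Homo sapiens), read by a luciferase reporter, with a stated time of 18 h (a higher number here means that more compound is needed for the effect, a lower number that less compound is needed), compound 1 gives 210 nM, the lowest of the three numbers. Compound 3 `CC(C)(C)OC(=O)N1CCC(CC(=O)N2CCC(NS(=O)(=O)c3cc(S(=O)(=O)c4ccccc4)ccc3C(F)(F)F)CC2)CC1` gives 400 nM, which sits within the scatter of compound 1. Compound 2 `O=S(=O)(NC1CCN(S(=O)(=O)c2cccc(-c3nnn[nH]3)c2)CC1)c1cc(S(=O)(=O)c2ccccc2)ccc1C(F)(F)F` gives 1200 nM, and the step of a 5.7-fold higher number from compound 1 to compound 2 (0.76 log units; beyond the scatter) is the only one that clearly moves the number; it puts a 1H-tetrazol-5-yl in place of hydrogen on an aromatic carbon.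

Compound 4 `O=C([C@@H]1CCNC1)N1CCC(NS(=O)(=O)c2cc(S(=O)(=O)c3ccccc3)ccc2C(F)(F)F)CC1` differs from compound 1 at that same cap: (pyrrolidin-3-yl)carbonyl in place of phenylsulfonyl on an amine nitrogen in a ring. Going by the values given here, no measured step covers this exact exchange. What bears on it is that compound 3, which also carries a carbonyl group on the ring nitrogen instead of the sulfonyl cap, stays within the scatter of compound 1, while compound 2 shows that changes at this cap can push the number up by a modest amount. The expectation for compound 4 is therefore a small shift, if any, from compound 1, with the step of a 1.9-fold higher number from compound 1 to compound 4 (0.28 log units; within the scatter) estimated to be no larger than modest. Compound 4 is expected to give about 400 nM in this assay, within a range from 150 nM to 1200 nM.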

Compound 4, half-maximal effective concentration: 380 nM
Beside the measured number, compound 4's estimate is 1.1-fold (0.02 log units) above it; the measured number falls inside the stated range.
By their numbers in this assay, from the lowest: compounds 1, 4 and 3 (each within the scatter of the next); then compound 2.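

Replacing the whole phenylsulfonyl cap on the amine nitrogen in a ring with (pyrrolidin-3-yl)carbonyl gives a 1.8-fold higher number from compound 1 to compound 4 (0.26 log units; within the scatter) in this assay, so at this position neither the sulfonyl nor the six-membered aromatic ring of the cap is required to keep the number within the scatter. Going by these compounds alone, the only earlier step at this cap kept the phenylsulfonyl and added a 1H-tetrazol-5-yl to it, giving a 5.7-fold higher number from compound 1 to compound 2 (0.76 log units; beyond the scatter), so the cap is not indifferent to every change, and compound 2 stands against any broad claim of tolerance. No measurement shown here explains why the number holds through so large an exchange of atoms, one that also brings in a hydrogen-bond donor and a defined stereocentre.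

The compounds shown leave open whether the hand of that stereocentre matters, as the mirror-image pyrrolidine does not appear among them, and whether the hydrogen on the pyrrolidine nitrogen matters, which an N-methylpyrrolidine would test. They also leave open whether any ring is needed in the cap at all, a question that a plain acetyl group would address.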